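Swapping the para-iodo for a hydroxy on the ketone ring

The compounds below may be only part of what the source reports. "The series", "measured", "known", "first", "only" and "open" are said of these compounds alone.

Measured so far:
Compound 1, `O=C(/C=C/c1ccc2c(c1)B(O)OC2)c1ccc(F)cc1`: 2800 nM
Compound 2, `O=C(/C=C/c1ccc2c(c1)B(O)OC2)c1ccc(I)cc1`: 11600 nM

Among the measured compounds shown here, in a functional assay on HCT-116 cells (Homo sapiens) for cytotoxicity, read by MTT assay, with a stated time of 48 h (on this read-out higher numbers stand for weaker inhibition and lower numbers for stronger inhibition), compound 2 gives the higher of the two numbers; its only neighbour is compound 1, and a 4.1-fold higher number from compound 1 to compound 2 (0.62 log units; beyond the scatter) separates them, a change of iodo in place of fluoro on an aromatic carbon. Compound 3, `O=C(/C=C/c1ccc2c(c1)B(O)OC2)c1ccc(O)cc1`, is not yet measured. It differs from compound 2 by hydroxy in place of iodo on an aromatic carbon, which turns 4-iodophenyl into 4-hydroxyphenyl. For the measured compounds named here, only that one step bears on this change, and it moved the number modestly when a small group became a large one. The reverse move, back to a small group, is expected to give a modestly lower number, roughly a 2.6-fold lower number from compound 2 to compound 3 (0.41 log units; beyond the scatter). Compound 3 is therefore estimated at 4500 nM, within 1500 nM to 14000 nM.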

Compound 3, half-maximal inhibitory concentration: 24100 nM
Beside the measured number, compound 3's estimate is 5.4-fold (0.73 log units) below it; the whole stated range lies below it.
By their numbers in this assay, from the lowest: compound 1; then compound 2; then compound 3.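

In this assay hydroxy in place of iodo gives a 2.1-fold higher number from compound 2 to compound 3 (0.32 log units; beyond the scatter) and hydroxy in place of fluoro gives an 8.6-fold higher number from compound 1 to compound 3 (0.93 log units; beyond the scatter) at the same ring position. Moving away from iodo therefore does not by itself lower the number here: hydroxy, which alone among the three groups brings a hydrogen-bond donor and acceptor, gives the highest number, and fluoro the lowest. Nothing available explains this rise. As far as these compounds go, whether an amine, a methoxy group or a chloro group would fall nearer fluoro or nearer hydroxy remains open.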